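Compound 3 to compound 4: methoxy replaced on the chain

The compounds below may be only part of what the source reports. "The series", "measured", "known", "first", "only" and "open" are said of these compounds alone.

In an ADME assay on microsomes from liver (Rattus norvegicus) for metabolic stability (on this read-out higher numbers stand for a longer-lived compound and lower numbers for a shorter-lived compound), compound 3 `CC#C[C@@H](Cc1nnn[nH]1)c1ccc(OCc2ccc3scc(-c4ccc(OCCOC)cc4C)c3c2)cc1` gives 0.217 h. Compound 2 `CC#C[C@@H](Cc1nnn[nH]1)c1ccc(OCc2ccc3scc(-c4cc(OCCOC)ccc4C)c3c2)cc1` gives 0.367 h, and the step of a 1.7-fold lower number from compound 2 to compound 3 (0.23 log units; within the scatter) leaves these two level. Compound 1 `CC#C[C@@H](Cc1nnn[nH]1)c1ccc(OCc2ccc3scc(-c4ccc(OCCCS(C)(=O)=O)cc4C)c3c2)cc1` gives 1.48 h, clearly longer-lived than compound 3.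

Compound 4 `CC#C[C@@H](Cc1nnn[nH]1)c1ccc(OCc2ccc3scc(-c4ccc(OCCC(C)(C)O)cc4C)c3c2)cc1` differs from compound 3 as follows: 1-hydroxy-1-methylethyl in place of methoxy on a saturated chain carbon, two bonds along the chain from an oxygen on an aromatic ring. The change is on a saturated chain carbon, two bonds along the chain from an oxygen on an aromatic ring, so 2-methoxyethoxy becomes 3-hydroxy-3-methylbutoxy.

Within the data shown here, the step of a 6.8-fold lower number from compound 1 to compound 3 (0.83 log units; beyond the scatter) is the only measured change at this place, and it shows that methoxy there goes with the shorter half-life. The step of a 1.7-fold lower number from compound 2 to compound 3 (0.23 log units; within the scatter) moves the whole chain and says little here. With one precedent, involving a different group, only part of that size is carried over. The expected move is upward, an estimated 2.8-fold higher number from compound 3 to compound 4 (0.44 log units; beyond the scatter). For compound 4 the estimated half-life is 0.6 h, with an expected range of 0.25 h to 1.4 h.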

Compound 4, half-life: 1.03 h
For compound 4 the middle estimate is 1.7-fold (0.23 log units) below the measured one; the range from low to high includes it.
By their numbers in this assay, from the lowest: compounds 3 and 2 (each within the scatter of the next); then compounds 4 and 1 (each within the scatter of the next).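

In this assay, a 4.7-fold higher number from compound 3 to compound 4 (0.68 log units; beyond the scatter) gives a second replacement for methoxy at this chain carbon that goes with a longer half-life, and this one carries no sulfonyl group, so the earlier gain was not unique to (methylsulfonyl)methyl. With a 1.4-fold lower number from compound 1 to compound 4 (0.16 log units; within the scatter), 1-hydroxy-1-methylethyl and (methylsulfonyl)methyl stand level at this carbon, and the series does not separate them on half-life. Nothing measured here accounts for the step from methoxy.

Still open, as far as these compounds go, is whether the hydroxyl or the methyl branches of 1-hydroxy-1-methylethyl carry the step, which a tert-butyl or a hydroxymethyl at the same carbon would help to separate. Also open, from the compounds shown here alone, is whether 3-hydroxy-3-methylbutoxy behaves the same way in the arrangement of compound 2.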